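Aryl hydrazone swaps on a shared core

The source may report more compounds than this note shows. Statements on the series, on what has been measured and on what is new or still open speak of the compounds shown alone.

Measured so far:
compound 1 `Cn1c(=O)c(=O)n(C2CCCC2)c2nc(N/N=C/c3cccs3)ncc21` gives 75600 nM in a functional assay on PC-3 cells (Homo sapiens) for antiproliferative activity, read by MTT assay; a lower number here means a stronger inhibitor, a higher number a weaker inhibitor
compound 2 `Cc1ccc(/C=N/Nc2ncc3c(n2)n(C2CCCC2)c(=O)c(=O)n3C)cc1C` gives 39000 nM
compound 3 `Cn1c(=O)c(=O)n(C2CCCC2)c2nc(N/N=C/c3cccc(O)c3)ncc21` gives 36300 nM

Compound 3 holds the lowest of the three numbers; compound 2 lies within the scatter of it (a 1.1-fold lower number from compound 2 to compound 3 (0.03 log units; within the scatter)), and only compound 1 stands apart (a 2.1-fold lower number from compound 1 to compound 3 (0.32 log units; beyond the scatter)). Compound 4 `Cn1c(=O)c(=O)n(C2CCCC2)c2nc(N/N=C/c3ccccc3Cl)ncc21` carries 2-chlorophenyl in place of 3-hydroxyphenyl on a carbon with a double bond to nitrogen. Within the data shown here, the steps that bear on this change are the two aryl swaps on the same carbon, a 1.1-fold lower number from compound 2 to compound 3 (0.03 log units; within the scatter) and a 2.1-fold lower number from compound 1 to compound 3 (0.32 log units; beyond the scatter), one within the scatter and one just beyond it. Exchanging one six-membered aromatic ring of carbon only for another is therefore expected to move this assay little, if at all beyond the scatter: a 1.1-fold higher number from compound 3 to compound 4 (0.04 log units; within the scatter). Compound 4 is estimated at 40000 nM, with a range from 15000 nM to 100000 nM.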

Compound 4, half-maximal inhibitory concentration: 16300 nM
Compound 4: the middle estimate sits 2.5-fold (0.39 log units) above what was measured, within the range that was stated.
By their numbers in this assay, from the lowest: compound 4; then compounds 3, 2 and 1 (each within the scatter of the next, the first and the last beyond it).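

Among six-membered aromatic rings on the carbon with a double bond to nitrogen, the exchange need not stay within the scatter in this assay: 2-chlorophenyl gives a 2.2-fold lower number from compound 3 to compound 4 (0.35 log units; beyond the scatter) and a 2.4-fold lower number from compound 2 to compound 4 (0.38 log units; beyond the scatter). The widest step at this position is now a 4.6-fold lower number from compound 1 to compound 4 (0.67 log units; beyond the scatter), which leaves compound 4 beyond the scatter of all three other compounds. Nothing measured here explains these steps.

No compound shown separates the chlorine from its place on the ring. From the compounds shown here alone, how an amine or a carboxylic acid on this phenyl ring would read also remains open.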